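The compounds below may be only part of what the source reports. "The series", "measured", "known", "first", "only" and "open" are said of these compounds alone.

In a functional assay on SW480 cells (Homo sapiens) for antiproliferative activity, read by MTT assay, with a stated time of 48 h (on this read-out higher numbers stand for weaker inhibition and lower numbers for stronger inhibition), compound 1 `CCN(CC)C/C1=C/C[C@](C)(CCC=C(C)C)/C=C/[C@@H](OC(=O)C=C(C)C)[C@](C)(O)/C=C/C1=O` gives 270 nM and compound 2 `CC(=O)O[C@@H]1/C=C/[C@@](C)(CCC=C(C)C)C/C=C(/CO)C(=O)/C=C/[C@@]1(C)O` gives 4900 nM. Compound 2 thus holds the higher of the two numbers, beyond the scatter of compound 1. Compound 3 `COCO[C@@H]1/C=C/[C@@](C)(CCC=C(C)C)C/C=C(/CO)C(=O)/C=C/[C@@]1(C)O` has methoxymethyl in place of acetyl on an oxygen on a saturated carbon. Among the compounds with values here, no measured pair isolates this change, and no step beyond the scatter is expected in this assay, in either direction. The estimated step of a 1.1-fold lower number from compound 2 to compound 3 (0.04 log units; within the scatter) is therefore small. For compound 3 the expected value is 4500 nM, with an estimated range of 1500 nM to 13000 nM.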

Compound 3, half-maximal inhibitory concentration: > 40000 nM
Compound 3 gave a limit, no number (the forecaster's own chance of this, stated with the estimate: 5%); at least 8.8-fold (0.94 log units) between middle value and limit.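

In this assay, this oxygen on a saturated carbon is sensitive to what it carries: methoxymethyl in place of acetyl, with the same count of heavy atoms, gives an at least 8.1-fold higher number from compound 2 to compound 3 (0.91 log units; beyond the scatter). Compound 3 stands at a limit of the assay, not at a number: the limit of > 40000 nM in this assay, at which 1 of the 3 values shown sits. The true size of the step from acetoxy to methoxymethoxy therefore stays unresolved, and only its lower bound can be read.

Open, as far as these compounds go, is how a free hydroxyl or a longer acyl chain on this oxygen would read out. Also open, from the compounds shown here alone, is whether a carbamate here would hold the value of compound 2, 4900 nM.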